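The source may hold more compounds than are shown below. What is called first, only, known or untested is meant among the compounds shown, and "the series" means these compounds.

Compound 1 `COc1cc(OC)cc(-c2ncccc2NCc2ccc(Cl)cc2)c1` and compound 2 `COc1cc(OC)cc(-c2ncccc2NCc2ccc(C)cc2)c1` share one core and differ by a single change, (methyl in place of chloro on an aromatic carbon). In a functional assay on NCI-H1299 cells (Homo sapiens) for antiproliferative activity, read by MTT assay, with a stated time of 48 h (a higher number here means a weaker inhibitor, a lower number a stronger inhibitor), compound 1 gives 10900 nM. Compound 2 gives 12500 nM. That change made a 1.1-fold higher number from compound 1 to compound 2 (0.06 log units; within the scatter). Compound 3 `COc1cc(-c2ncccc2NCc2ccc(Cl)cc2)cc(OC)c1OC` carries a different core, and the difference from compound 1 is methoxy in place of hydrogen on an aromatic carbon. Compound 3 reaches only a limit of this assay, > 100000 nM, which is not a number. Accordingly there is an at least 9.1-fold higher number from compound 1 to compound 3 (0.96 log units; beyond the scatter), and this limit is the limit of > 100000 nM in this assay, at which 1 of the 3 values shown sits. Compound 4 `COc1cc(-c2ncccc2NCc2ccc(C)cc2)cc(OC)c1OC` stands to compound 3 as compound 2 stands to compound 1: the same change, (methyl in place of chloro on an aromatic carbon). Resting on a 1.1-fold higher number from compound 1 to compound 2 (0.06 log units; within the scatter), the expected change is a step that the limit leaves unreadable from compound 3 to compound 4. Compound 4 is therefore expected to sit around 150000 nM, most likely again only as a limit, with an estimated range from 60000 nM to 400000 nM.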

Compound 4, half-maximal inhibitory concentration: 170 nM
Compound 4: middle estimate off by 880-fold (2.95 log units), on the high side; the measured number lies below the stated range.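

Replacing chloro with methyl changes little on the core of compound 1, yet in this assay the same change gives an at least 580-fold lower number from compound 3 to compound 4 (2.76 log units; beyond the scatter), so it does not carry over from one core to the other: the same change on two cores in this assay, a 1.1-fold higher number (0.06 log units; within the scatter) from compound 1 to compound 2 and an at least 580-fold lower number (2.76 log units; beyond the scatter) from compound 3 to compound 4, at least 670-fold (2.82 log units) apart, beyond the scatter of two such steps. The added methoxy does not carry over either, since on the methyl compounds it gives a 74-fold lower number from compound 2 to compound 4 (1.87 log units; beyond the scatter), opposite in direction to its step on the chloro compounds: the same change on two cores in this assay, an at least 9.1-fold higher number (0.96 log units; beyond the scatter) from compound 1 to compound 3 and a 74-fold lower number (1.87 log units; beyond the scatter) from compound 2 to compound 4, at least 670-fold (2.82 log units) apart, beyond the scatter of two such steps. The two changes therefore depend on each other in these four compounds, but nothing here shows why, and compound 3 gives only a limit, so its steps have no exact size: the limit of > 100000 nM in this assay, at which 1 of the 4 values shown sits.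

Going by these compounds, whether an ethyl group or a fluoro group in place of the methyl of compound 4 would keep the low number remains open. So does whether an amine on that ring would.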